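This account rests on a few compounds, and the source may have more. Where it says the series, first, only, none or still open, it means among the compounds named here.

Measured so far in a functional assay on MC-38 cells (Mus musculus) for antiproliferative activity, read by CCK-8 assay, with a stated time of 48 h; a lower number here means a stronger inhibitor, a higher number a weaker inhibitor:
Compound 1 `COc1ccc(/C=C\c2cc(OC)c(OC)c(OC)c2)cc1OCc1ccc(CN2CC[C@H](C(=O)O)C2)cc1` gives only a limit, > 10000 nM.
Compound 2 `COc1ccc(/C=C\c2cc(OC)c(OC)c(OC)c2)cc1OCc1ccc(CN2CCCCC2C(=O)O)cc1` gives 5400 nM.
Compound 3 `COc1ccc(/C=C\c2cc(OC)c(OC)c(OC)c2)cc1OCc1ccc(CN2CC[C@@H](O)C2)cc1` gives 6900 nM.

Compound 1 therefore stands at the edge of the run: the limit of > 10000 nM in this assay, at which 1 of the 3 values shown sits, and no number is known for it, only that it lies beyond what this assay resolves. The step to compound 4 `COc1ccc(/C=C\c2cc(OC)c(OC)c(OC)c2)cc1OCc1ccc(CNCCN(C)C)cc1` is (2-(dimethylamino)ethyl)amino in place of 3-carboxypyrrolidin-1-yl on a saturated chain carbon bound to an aromatic carbon. Two measured steps leave the same group from the same place: an at least 1.8-fold lower number from compound 1 to compound 2 (0.26 log units; that floor lies within the scatter) and an at least 1.4-fold lower number from compound 1 to compound 3 (0.16 log units; that floor lies within the scatter); between the two replacements a 1.3-fold higher number from compound 2 to compound 3 (0.11 log units; within the scatter). Both exchanges of the 3-carboxypyrrolidin-1-yl group returned a number instead of a limit, though each floor lies within the scatter, so the true size of either step is open. The exchange to (2-(dimethylamino)ethyl)amino likewise removes the 3-carboxypyrrolidin-1-yl group, so a number rather than a limit is the more likely outcome. In this assay compound 4 is expected to land roughly where compound 2 and compound 3 sit. From compound 1 the step is estimated as an at least 1.8-fold lower number from compound 1 to compound 4 (0.25 log units; that floor lies within the scatter). Compound 4 is accordingly estimated at 5500 nM, between 2000 nM and 15000 nM, with a real chance that only a limit is reported again.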

Compound 4, half-maximal inhibitory concentration: 1400 nM
For compound 4 the middle estimate is 3.9-fold (0.59 log units) above the measured one; the measured number lies below the stated range.
By their numbers in this assay, from the lowest: compound 4; then compounds 2 and 3 (each within the scatter of the next). At a limit, above all of these: compound 1.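

In this assay, going by these compounds alone, (2-(dimethylamino)ethyl)amino is the first group at this place, on a saturated chain carbon bound to an aromatic carbon, to give a change that clears the scatter, with a 4.9-fold lower number from compound 3 to compound 4 (0.69 log units; beyond the scatter) and a 3.9-fold lower number from compound 2 to compound 4 (0.59 log units; beyond the scatter). Removing the carboxylic acid is not enough on its own to give this change, as compound 3 carries 3-hydroxypyrrolidin-1-yl and no carboxylic acid, yet its step from compound 2 stays within the scatter; among the four compounds, compound 4 alone has no ring in this group. The step of an at least 7.1-fold lower number from compound 1 to compound 4 (0.85 log units; beyond the scatter) is only a floor, since compound 1 remains a limit rather than a number: the limit of > 10000 nM in this assay, at which 1 of the 4 values shown sits.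

The compounds shown do not separate the loss of the ring from the arrival of the terminal dimethylamino group, as both change together in compound 4. On these data alone, how this place responds to a longer chain between the two nitrogens, a primary amine at the chain end, or a piperazine that keeps both nitrogens within a ring remains open.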